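The source may hold more compounds than are shown below. What is called first, only, known or untested is meant among the compounds shown, and "the series" means these compounds.

For the measured compounds named here, compound 1 (`C=C(Br)C(=O)Nc1cccc(/C=C/C(=O)Nc2ccccc2)c1`) gives 16600 nM in a functional assay on HT-29 cells (Homo sapiens) for inhibition, read by MTT assay, with a stated time of 72 h (a higher number here means a weaker inhibitor, a lower number a stronger inhibitor), and holds the higher of the two numbers so far. Going by the values given here, compound 2 (`C=C(Br)C(=O)Nc1cccc(/C=C/C(=O)Nc2cccc(F)c2)c1`) gives 4600 nM in this assay and is the only comparison. Compound 3 (`C=C(Br)C(=O)Nc1cccc(/C=C/C(=O)Nc2ccc(OC)cc2)c1`) differs from compound 1 by methoxy in place of hydrogen on an aromatic carbon (methoxy in place of hydrogen on an aromatic carbon, para to a large group). Among the compounds with values here, the one measured step bearing on this is a 3.6-fold lower number from compound 1 to compound 2 (0.56 log units; beyond the scatter) (modest), and it involves a different group. A similar or smaller move to a lower number is therefore expected in this assay (estimated as a 1.7-fold lower number from compound 1 to compound 3 (0.22 log units; within the scatter) here). The estimated value for compound 3 is 10000 nM (range 4000 nM to 25000 nM).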

Compound 3, half-maximal inhibitory concentration: 2300 nM
Compound 3: the middle estimate sits 4.3-fold (0.64 log units) above what was measured, outside the stated range (below it).
By their numbers in this assay, from the lowest: compounds 3 and 2 (each within the scatter of the next); then compound 1.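

In this assay, phenyl to 4-methoxyphenyl gives a 7.2-fold lower number from compound 1 to compound 3 (0.86 log units; beyond the scatter) and thus shows that this ring tolerates methoxy, para to a large group, with a clear gain over the unsubstituted compound 1. Fluoro is therefore not the only substituent on this ring to lower the number, and the change to methoxy gives a 2.0-fold lower number from compound 2 to compound 3 (0.30 log units; within the scatter) with no separation between these two substituted compounds. No measurement available here explains the size of either step. Open, going by these compounds, is whether an amine or a carboxylic acid, para to a large group, would give a similar number. Also open, on these data alone, is whether methoxy would do the same elsewhere on this ring.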